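From cyclopropyl to ethyl on a saturated chain

The source may hold more compounds than are shown below. What is called first, only, known or untested is meant among the compounds shown, and "the series" means these compounds.

Compound 1 `Brc1cccc(Br)c1N(CC1CC1)C1=NCCN1` is a useful starting point: in a physicochemical assay for lipophilicity (on this read-out lower numbers stand for lower lipophilicity and higher numbers for higher lipophilicity), compound 1 gives -1.12. Compound 2 `Brc1ccc(Br)c(N(CC2CC2)C2=NCCN2)c1` gives -0.52, so compound 1 holds the lower of the two numbers, and the gap between them lies beyond the usual scatter of repeated measurements. Compound 3 `CCCN(C1=NCCN1)c1c(Br)cccc1Br` has not been measured yet. It keeps the core of compound 1 and differs in one place: ethyl in place of cyclopropyl on a saturated chain carbon bound to a nitrogen on an aromatic ring. Among the measured compounds shown here, no measured pair shows this change, so the expectation rests on judgement alone. The expected a number 0.12 log units higher from compound 1 to compound 3 (within the scatter) is a small rise in this assay, not beyond the scatter. Compound 3 is therefore expected at -1, with an estimated range from -1.4 to -0.6.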

Compound 3, distribution coefficient: -0.55
The estimate for compound 3 lay 0.45 log units below the measured number; measured number above the stated range.
By their numbers in this assay, from the lowest: compound 1; then compounds 3 and 2 (each within the scatter of the next).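

Among the compounds shown here, this is the first pair in the set that differs in only one place, so it isolates the change: ethyl in place of cyclopropyl, on a saturated chain carbon bound to a nitrogen on an aromatic ring, gives in this assay a number 0.57 log units higher from compound 1 to compound 3 (beyond the scatter). The position is therefore not indifferent to what it carries: replacing the three-membered ring with an open group that has no ring moves the number by more than repeat measurements would. The data offer no measured explanation for this shift.

Going by these compounds, whether a longer chain such as butyl, or an amine on the chain, would move the number further remains open. So does whether the same change would give a similar step on compound 2, whose two bromines are placed differently.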